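The source may hold more compounds than are shown below. What is called first, only, known or untested is meant among the compounds shown, and "the series" means these compounds.

Of the compounds shown here, two have been measured so far in a functional assay on PC-3 cells (Homo sapiens) for antiproliferative activity, read by sulforhodamine B assay, with a stated time of 48 h, tested at 50 uM; on this read-out lower numbers stand for less inhibition and higher numbers for more inhibition at the one concentration tested (going by the name of the read-out). Compound 1 `CC1=CC[C@H](C(C)C)c2cc(C)c(OC(=O)Nc3ccccc3)cc21` gives 93.2% in this assay. Compound 2 `CC1=CC[C@H](C(C)C)c2cc(C)c(OC(=O)c3cccc(Cl)c3)cc21` gives 23.4% in this assay, the lowest of the two numbers; its nearest neighbour is compound 1, and the step of a number 69.8 percentage points lower from compound 1 to compound 2 (beyond the scatter) lies beyond the scatter. Compound 3 `CC1=CC[C@H](C(C)C)c2cc(C)c(OC(=O)c3cccc([N+](=O)[O-])c3)cc21` has not yet been measured. It differs from compound 2 by nitro in place of chloro on an aromatic carbon. Among the compounds with values here, no measured step alters a substituent on the six-membered aromatic ring of carbon only; the single step known, a number 69.8 percentage points lower from compound 1 to compound 2 (beyond the scatter), exchanges the whole group on the carbonyl carbon, so it bears on the step from compound 2 to compound 3 only by showing that this part of the molecule can move the read-out a long way. With no closer comparison available, the step to compound 3 in this assay is expected to be small or none beyond the scatter, in either direction, as a number 6.6 percentage points higher from compound 2 to compound 3 (within the scatter). Compound 3 is therefore estimated at 30%, with a range from 5% to 60%.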

Compound 3, a percentage reported as inhibition, at one concentration (the size of the read-out at that concentration, not a potency): 36.9%
For compound 3 the middle estimate is 6.9 percentage points below the measured one; the range from low to high includes it.
By their numbers in this assay, from the lowest: compound 2; then compound 3; then compound 1.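

Nitro in place of chloro on the aromatic ring gives in this assay a number 13.5 percentage points higher from compound 2 to compound 3 (beyond the scatter), the first measured sign that a substituent at this place, on this ring, moves the read-out beyond the scatter, although the step is only modest. The ring substituent does not close the gap to the carbamate: a number 56.3 percentage points lower from compound 1 to compound 3 (beyond the scatter) remains large, so with 3-nitrophenyl as with 3-chlorophenyl on the carbonyl carbon, the number lies far below that of the anilino compound. Nothing measured here explains why nitro and chloro differ at this place.

As far as these compounds go, two substituents give no trend, so it remains open whether an amine, a carboxylic acid or a methoxy group at the same place would continue the step from chloro to nitro or reverse it. Also open is whether chloro or nitro on the anilino ring of compound 1 would shift the read-out as they do here, and how any of these compounds would rank across a range of concentrations rather than at the single one tested.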